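Carbamoyl benzoxazolone series: ring swap at the aryl position

The source may report more compounds than this note shows. Statements on the series, on what has been measured and on what is new or still open speak of the compounds shown alone.

Three compounds in the series carry a measured number in an assay on HEK293 cells for inhibition of acid ceramidase (Homo sapiens), read by fluorescence, with stated times of 10 min and 3 h; a lower number here means a stronger inhibitor, a higher number a weaker inhibitor. Compound 1 `CC(C)CNC(=O)n1c(=O)oc2ccc(C3CCN(C)CC3)cc21` gives 295 nM in this assay. Compound 2 `O=C(NCCCCc1ccccc1)n1c(=O)oc2cc(C3CCCCC3)ccc21` gives 89 nM in this assay. Compound 3 `CN1CCC(c2cc3oc(=O)n(C(=O)NCCCCc4ccccc4)c3cc2F)CC1` gives 24 nM in this assay. Compound 2 thus stands second highest of the three numbers: compound 1 lies above it, beyond the scatter, and compound 3 lies below it, also beyond the scatter. Compound 4 `CN1CCN(c2ccc3c(c2)oc(=O)n3C(=O)NCCCCc2ccccc2)CC1=O` has not yet been measured in this assay. It keeps the phenylbutyl carbamoyl side of compound 2 and differs from compound 2 in one place: 4-methyl-3-oxopiperazin-1-yl in place of cyclohexyl on an aromatic carbon. For the measured compounds named here, no measured pair shows this change directly, so the size of the step has to be guessed from the spread of the three numbers. The expectation is a weakening beyond the scatter, of the order of the step from compound 2 to compound 4 given as a 2.0-fold higher number from compound 2 to compound 4 (0.31 log units; beyond the scatter). Compound 4 is estimated at 180 nM in this assay, with a range from 45 nM to 700 nM.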

Compound 4, half-maximal inhibitory concentration: 92 nM
Compound 4: middle estimate off by 2.0-fold (0.29 log units), on the high side, and the stated range covers the measured number.
By their numbers in this assay, from the lowest: compound 3; then compounds 2 and 4 (each within the scatter of the next); then compound 1.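

For the compounds shown here, replacing cyclohexyl with 4-methyl-3-oxopiperazin-1-yl on this aromatic carbon gives a 1.0-fold higher number from compound 2 to compound 4 (0.01 log units; within the scatter) in this assay, the first direct reading of a ring swap at this position. The position therefore carries a ring of carbon only or a ring with 2 hetero atoms and 2 hydrogen-bond acceptors, with the phenylbutyl carbamoyl side kept and no difference beyond the scatter. Nothing at hand bears on why the two rings read alike.

Compound 1 and compound 3 differ from compound 2 and compound 4 in more than one place, so their steps cannot be read. As far as these compounds go, it remains open whether a morpholine ring, an open-chain amine or a carboxylic acid on this carbon would also leave the number within the scatter.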